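Hydroxyl position on the furan-bearing core

The compounds below may be only part of what the source reports. "The series", "measured", "known", "first", "only" and "open" are said of these compounds alone.

Compound 3 `Oc1cccc(-c2cc(-c3ccco3)cc(-c3cccc(O)c3)n2)c1` gives 97.8% in an assay on isolated protein for inhibition of DNA topoisomerase 1 (Homo sapiens), with a stated time of 30 min, tested at 100 uM; on this read-out higher numbers stand for a stronger effect at the one concentration tested and lower numbers for a weaker effect. Compound 2 `Oc1cccc(-c2cc(-c3ccco3)cc(-c3ccccc3O)n2)c1` gives 90.1%, within the scatter of compound 3; compound 1 `Oc1ccc(-c2cc(-c3ccsc3)cc(-c3cccc(O)c3)n2)cc1` gives 17.1%, far below both. Compound 4 `Oc1ccc(-c2cc(-c3ccco3)cc(-c3cccc(O)c3)n2)cc1` carries 4-hydroxyphenyl in place of 3-hydroxyphenyl on an aromatic carbon. Among the compounds with values here, the only measured step of a similar kind, a number 7.7 percentage points higher from compound 2 to compound 3 (within the scatter), was within the scatter, which suggests moving the hydroxyl has little effect. Compound 1, however, also carries a 4-hydroxyphenyl group together with a thiophen-3-yl group and sits low in this assay, so some fall cannot be excluded. A modest drop, a number 22.8 percentage points lower from compound 3 to compound 4 (beyond the scatter), is therefore expected. Compound 4 is estimated at 75%, within 30% to 98%.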

Compound 4, a percentage reported as inhibition, at one concentration (the size of the read-out at that concentration, not a potency): 100%
Compound 4: the middle estimate sits 25 percentage points below what was measured, and the stated range ends below it.
By their numbers in this assay, from the lowest: compound 1; then compounds 2, 3 and 4 (each within the scatter of the next).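

In this assay, exchanging 3-hydroxyphenyl for 4-hydroxyphenyl gives a number 2.2 percentage points higher from compound 3 to compound 4 (within the scatter), and exchanging 2-hydroxyphenyl for 4-hydroxyphenyl gives a number 9.9 percentage points higher from compound 2 to compound 4 (within the scatter), so these three hydroxyl placements read alike with furan-2-yl on the shared core. The large change lies instead with the other group: furan-2-yl in place of thiophen-3-yl gives a number 82.9 percentage points higher from compound 1 to compound 4 (beyond the scatter). Nothing available explains this difference.

Open, as far as these compounds go, is whether an amine or a methoxy group in place of the hydroxyl would hold the read-out. A single concentration also leaves open how compound 2, compound 3 and compound 4 would compare at other concentrations, since their effects at the one concentration tested read alike.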